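Changing the Aryl Group on the Amine Nitrogen

The compounds below may be only part of what the source reports. "The series", "measured", "known", "first", "only" and "open" are said of these compounds alone.

Compound 2 `COc1cc(NC(=O)Nc2cc(Nc3ccc(OC)c(C)c3)ncn2)cc(OC)c1` is the lower of the two compounds measured in a functional assay on PC-9 cells (Homo sapiens) for inhibition, read by MTT assay, with a stated time of 48 h, tested at 10 uM (on this read-out lower numbers stand for less inhibition and higher numbers for more inhibition at the one concentration tested (going by the name of the read-out)), where compound 2 gives 62%. Compound 1 `COc1cc(NC(=O)Nc2cc(Nc3ccc(C(C)(C)C)cc3)ncn2)cc(OC)c1` gives 74.1%. For the measured compounds named here, the single measured step, a number 12.1 percentage points lower from compound 1 to compound 2 (beyond the scatter), put 4-methoxy-3-methylphenyl in place of 4-(tert-butyl)phenyl on a nitrogen on an aromatic ring. Compound 3 `COc1cc(NC(=O)Nc2cc(Nc3cc(C)cc(F)c3)ncn2)cc(OC)c1` alters that same group once more: 3-fluoro-5-methylphenyl in place of 4-methoxy-3-methylphenyl on a nitrogen on an aromatic ring. Going by the values given here, only that one step touches this place, and neither of its groups is 3-fluoro-5-methylphenyl, so for compound 3 the expected step is a number 2 percentage points lower from compound 2 to compound 3 (within the scatter), within the scatter. Compound 3 is therefore estimated at 60%, between 42% and 78%.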

Compound 3, a percentage reported as inhibition, at one concentration (the size of the read-out at that concentration, not a potency): 64.5%
Compound 3: the middle estimate sits 4.5 percentage points below what was measured; measured number inside the range.
By their numbers in this assay, from the lowest: compounds 2, 3 and 1 (each within the scatter of the next, the first and the last beyond it).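

In this assay, the oxygen of 4-methoxy-3-methylphenyl is not needed to keep the reading at this nitrogen: 3-fluoro-5-methylphenyl, with no hydrogen-bond acceptor, gives a number 2.5 percentage points higher from compound 2 to compound 3 (within the scatter). The other comparison, a number 9.6 percentage points lower from compound 1 to compound 3 (within the scatter), means compound 3 cannot be told apart from either neighbour, even though compound 1 and compound 2 differ beyond the scatter. Nothing available here explains these readings. Still open, on these data alone, is how an amine or a carboxylic acid on this aryl ring would read, and whether a plain alkyl chain could replace the ring altogether.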